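The compounds below may be only part of what the source reports. "The series", "measured", "known", "first", "only" and "open" are said of these compounds alone.

Measured so far:
compound 1 `Nc1nc(-c2ccc(Cl)cc2)c(CC(=O)O)s1`: > 100000 nM
compound 2 `CCC(c1ccccc1)c1nc(-c2ccc(Cl)cc2)c(CC(=O)O)s1`: 190 nM

Compound 1 stands at the limit of > 100000 nM in this assay, at which 1 of the 2 values shown sits; that figure is a limit of the assay and not a number, so where compound 1 truly sits on this read-out is not fixed. In an in vitro assay on HEK385-7 cells for displacement of a labelled ligand from prostaglandin D2 receptor 2 (Homo sapiens) (on this read-out higher numbers stand for weaker inhibition and lower numbers for stronger inhibition), compound 2 gives 190 nM, a measured number rather than a limit. Compound 3 `O=C(O)Cc1sc(NCc2ccccc2)nc1-c1ccc(Cl)cc1` has not been measured in this assay. It differs from compound 1 by benzyl in place of hydrogen on a nitrogen on an aromatic ring. Within the data shown here, no step between measured compounds is available to set a scale, so the size of this step is open; what the two measured values show is that, on the shared core, a limit and a clearly measured number both occur, and the expectation for compound 3 is a step toward stronger inhibition, well beyond the scatter, though with wide uncertainty. The value expected for compound 3 is 2000 nM, with a range from 200 nM to 20000 nM. The step this estimate implies is an at least 50-fold lower number from compound 1 to compound 3 (1.69 log units; beyond the scatter).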

Compound 3, half-maximal inhibitory concentration: 440 nM
The estimate for compound 3 lay 4.5-fold (0.66 log units) above the measured number, within the range that was stated.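

In this assay, the nitrogen on the aromatic ring of the shared core tolerates substitution: benzyl in place of hydrogen there gives an at least 220-fold lower number from compound 1 to compound 3 (2.35 log units; beyond the scatter), a change that lies beyond the scatter. Among these compounds, this is the first step that can be read in one place, so it shows that this single change is enough to move the amino compound from the end of the assay's range to a measured number. The size printed for the step is only a lower bound, and the real size stays unfixed because compound 1 is held at a limit and not at a number: the limit of > 100000 nM in this assay, at which 1 of the 3 values shown sits.

The compounds shown leave open whether the phenyl ring of the benzyl group is what matters, or whether a plain methyl or a longer alkyl chain on the same nitrogen would give a similar shift. They also leave open how a phenethyl group, with a longer link to the ring, or a methoxy or chloro substituent on the benzyl ring would read out, and whether the ring nitrogen's hydrogen can be replaced by a second methyl.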